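The source may hold more compounds than are shown below. What is called first, only, known or untested is meant among the compounds shown, and "the series" means these compounds.

Compound 1, `O=[N+]([O-])c1ccccc1CNc1cccc2[nH]ncc12`, is the starting point of this account, yet in an assay for inhibition of Indoleamine 2,3-dioxygenase 1 (Homo sapiens), with stated times of 10 min and 60 min (on this read-out lower numbers stand for stronger inhibition and higher numbers for weaker inhibition), compound 1 has no result, only the entry "nd" (no result reported). Its place among the numbers shown is therefore fixed only by its neighbours. Compound 2, `NCCn1ncc2c(NCc3ccccc3[N+](=O)[O-])cc(C(F)(F)F)cc21`, reaches in this assay only a limit, > 100000 nM, and not a number. Compound 3, `COc1cc(CNc2cc(Br)cc3[nH]ncc23)c([N+](=O)[O-])cc1OC`, gives in this assay 18500 nM. Within the data shown here, the scale of the set is thus marked by the limit of > 100000 nM in this assay, at which 1 of the 3 values shown sits, with compound 3 as the one number that sits inside the measurable range.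

The step from compound 1 leads to compound 4, `O=[N+]([O-])c1ccccc1CNc1cc(Br)cc2[nH]ncc12`, through (bromo in place of hydrogen on an aromatic carbon), the bromo in place of hydrogen on an aromatic carbon. Among the measured compounds shown here, no measured pair in this set shows that same step, so no size can be read off for it; the expectation is a number in this assay of the same order as compound 3, with weak inhibition and a real chance of another limit. Compound 4 is estimated at 25000 nM, within a range from 6000 nM to 100000 nM.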

Compound 4, half-maximal inhibitory concentration: 8040 nM
The estimate for compound 4 lay 3.1-fold (0.49 log units) above the measured number; the measured number falls inside the stated range.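

In this assay, among these compounds, compound 1 has only the entry "nd" (no result reported), so no step from compound 1 to compound 4 can be read. The compounds shown leave open how much the bromo in place of hydrogen on an aromatic carbon changes inhibition.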